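Swapping the distal aryl ring on a glucagon antagonist core

The source may report more compounds than this note shows. Statements on the series, on what has been measured and on what is new or still open speak of the compounds shown alone.

Measured so far:
Compound 1, `CCCCC(Oc1ncc(-c2ccccc2)cn1)c1ccc(C(=O)NCCC(=O)O)cc1` — 4100 nM
Compound 2, `CCCC[C@@H](Oc1ncc(-c2ccccc2)cn1)c1ccc(C(=O)NCCC(=O)O)cc1` — 9300 nM
Compound 3, `CCCCC(Oc1ncc(-c2ccc(C(C)(C)C)cc2)cn1)c1ccc(C(=O)NCCC(=O)O)cc1` — 6000 nM

In a functional assay on cells for antagonist activity at Glucagon receptor (Homo sapiens), read by luminescence and cAMP accumulation, with stated times of 10 min and 30 min (a higher number here means a weaker inhibitor, a lower number a stronger inhibitor), compound 1 gives 4100 nM. Compound 2 differs only in that a stereocentre at a saturated chain carbon is drawn with a configuration, and the step is a 2.3-fold higher number from compound 1 to compound 2 (0.36 log units; beyond the scatter); the drawn configuration in one and not the other is the one point of difference here (the fact that one of compounds 1 and 2 is drawn with a defined configuration and the other without, at the place where they differ). Compound 3 carries a tert-butyl in place of hydrogen on an aromatic carbon, and the step of a 1.5-fold higher number from compound 1 to compound 3 (0.17 log units; within the scatter) lies within the scatter. Compound 3 thus sits within the scatter of both compound 1 and compound 2.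

Compound 4, `CCCCC(Oc1ncc(-c2cc(Cl)cc(Cl)c2)cn1)c1ccc(C(=O)NCCC(=O)O)cc1`, has not yet been measured. It differs from compound 3 by 3,5-dichlorophenyl in place of 4-(tert-butyl)phenyl on an aromatic carbon. Going by the values given here, the only measured step that touches this ring, from compound 1 to compound 3, was small, so no step beyond the scatter is expected in this assay for compound 4. The expected step is a 1.2-fold lower number from compound 3 to compound 4 (0.08 log units; within the scatter). Compound 4 is estimated to give 5000 nM, with a range from 1800 nM to 14000 nM.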

Compound 4, half-maximal inhibitory concentration: 6900 nM
Beside the measured number, compound 4's estimate is 1.4-fold (0.14 log units) below it, and the stated range covers the measured number.
By their numbers in this assay, from the lowest: compounds 1, 3, 4 and 2 (each within the scatter of the next, the first and the last beyond it).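

In this assay, the new result gives this position a second substituted ring to compare: 3,5-dichlorophenyl in place of 4-(tert-butyl)phenyl gives a 1.2-fold higher number from compound 3 to compound 4 (0.06 log units; within the scatter), and 3,5-dichlorophenyl in place of phenyl gives a 1.7-fold higher number from compound 1 to compound 4 (0.23 log units; within the scatter). Neither step leaves the scatter, so both a ring with two chlorines and a ring with a tert-butyl group now sit at this position with no step beyond it from the plain phenyl of compound 1. Nothing at hand bears on why these changes leave the number so little moved.

On these data alone, it remains open whether an amine or a carboxylic acid on this ring would produce a step beyond the scatter. As far as these compounds go, it is also open how 3,5-dichlorophenyl would behave with a defined configuration at the chain carbon.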